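Cyclohexyl Replacing Isopropyl on an Amide Nitrogen

The source may hold more compounds than are shown below. What is called first, only, known or untested is meant among the compounds shown, and "the series" means these compounds.

Of the compounds shown here, two built on the same core have been measured. Compound 1 `O=C(Nc1ccc(Cl)cc1)c1cc(Oc2ccc(/C=C/c3ccncc3)cc2)ccn1` gives 56200 nM in a functional assay on HepG2 cells (Homo sapiens) for antiproliferative activity, read by CCK-8 assay, with a stated time of 48 h (on this read-out higher numbers stand for weaker inhibition and lower numbers for stronger inhibition), and compound 2 `CC(C)NC(=O)c1cc(Oc2ccc(/C=C/c3ccncc3)cc2)ccn1` gives 33700 nM in this assay. Compound 2 thus holds the lowest of the two numbers, but the step of a 1.7-fold lower number from compound 1 to compound 2 (0.22 log units; within the scatter) is within the scatter, so the two compounds cannot be told apart on this evidence. Compound 3 `O=C(NC1CCCCC1)c1cc(Oc2ccc(/C=C/c3ccncc3)cc2)ccn1` is the next compound to be measured; it differs from compound 2 by cyclohexyl in place of isopropyl on an amide-type nitrogen. Within the data shown here, the only measured step, a 1.7-fold lower number from compound 1 to compound 2 (0.22 log units; within the scatter), concerns a different exchange at the same amide-type nitrogen and was within the scatter, so it gives no reason to expect a large move in either direction. The expected step of a 1.1-fold lower number from compound 2 to compound 3 (0.05 log units; within the scatter) therefore stays within the scatter. Compound 3 is expected to give about 30000 nM in this assay, with a likely range from 10000 nM to 90000 nM.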

Compound 3, half-maximal inhibitory concentration: 22400 nM
Beside the measured number, compound 3's estimate is 1.3-fold (0.13 log units) above it, within the range that was stated.
By their numbers in this assay, from the lowest: compounds 3, 2 and 1 (each within the scatter of the next, the first and the last beyond it).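

In this assay, cyclohexyl in place of isopropyl on the amide-type nitrogen gives a 1.5-fold lower number from compound 2 to compound 3 (0.18 log units; within the scatter), so these two groups cannot be told apart, even though only cyclohexyl carries a ring. Among these compounds, the one step at this nitrogen that passes the scatter is a 2.5-fold lower number from compound 1 to compound 3 (0.40 log units; beyond the scatter), with cyclohexyl in place of 4-chlorophenyl, and it is modest, while compound 2 stays within the scatter of both other compounds. No evidence is available to explain why the numbers fall as they do.

On these data alone, it remains open whether a smaller ring such as cyclopentyl, or an unbranched longer chain, would give a number distinct from these. A chain ending in an amine or a carboxylic acid on this nitrogen is equally untested by the compounds shown.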